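This account rests on a few compounds, and the source may have more. Where it says the series, first, only, none or still open, it means among the compounds named here.

Of the compounds shown here, three have been measured in a physicochemical assay for lipophilicity, read by HPLC, at pH 7.5; on this read-out lower numbers stand for lower lipophilicity and higher numbers for higher lipophilicity. Compound 1 `CC[C@@H](Nc1c(C#N)c(-c2ccc(-c3ccncc3C)cc2)nc2cnccc12)C(N)=O` gives 2, a number within the usual scatter of compound 3 `CCOc1ccccc1-c1ccc(-c2nc3cnccc3c(N[C@H](CC)C(=O)NS(C)(=O)=O)c2C#N)cc1` at 2.2 and of compound 2 `CCOc1ccccc1-c1ccc(-c2nc3cnccc3c(N[C@H](CC)C(=O)NS(=O)(=O)C3CC3)c2C#N)cc1` at 2.3. Within the data shown here, the one change between measured compounds, a number 0.10 log units lower from compound 2 to compound 3 (within the scatter), concerns a different part of the molecule and does not reach beyond the scatter. Compound 4 `CC[C@@H](Nc1c(C#N)c(-c2ccc(-c3ccccc3C(C)C)cc2)nc2cnccc12)C(N)=O` differs from compound 1 in one place: 2-isopropylphenyl in place of 3-methylpyridin-4-yl on an aromatic carbon. Among the measured compounds shown here, no measured step covers this exchange, so the expectation rests on the change itself, replacing a pyridine-containing group with one of carbon only and adding an isopropyl. A rise in this assay is expected, a number 1.30 log units higher from compound 1 to compound 4 (beyond the scatter). Compound 4 is therefore estimated at 3.3, in a range from 2.7 to 3.9.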

Compound 4, distribution coefficient: 3.5
Compound 4: middle estimate off by 0.20 log units, on the low side; low and high end bracket the measured number.
By their numbers in this assay, from the lowest: compounds 1, 3 and 2 (each within the scatter of the next); then compound 4.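

In this assay, 2-isopropylphenyl in place of 3-methylpyridin-4-yl, on an aromatic carbon para to a large group, gives a number 1.50 log units higher from compound 1 to compound 4 (beyond the scatter) and is the only step shown that lies beyond the scatter. The earlier step, at the sulfonyl sulfur, stayed within it, so this position is the one seen to move the read-out. Nothing available accounts for the size of this step.

The ring nitrogen and the isopropyl change together here, so their shares cannot be separated. Going by these compounds, how a plain phenyl or a 2-methylphenyl would read at this position remains open.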